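Swapping the amide for a carboxy group in a sulfur series

The compounds below may be only part of what the source reports. "The series", "measured", "known", "first", "only" and "open" are said of these compounds alone.

Measured in an ADME assay on the whole organism (plasma, strain F344/DuCrlCrlj) for pharmacokinetics, with Rattus norvegicus as the target, read by LC-MS, at a dose of 1 mg/kg by the oral route; on this read-out lower numbers stand for lower exposure and higher numbers for higher exposure at the dose given:
Compound 1 `COc1ccc2nc(COc3ccc(CC(SC)C(N)=O)cc3)n(C)c2c1`: 2.71 ng.h/mL
Compound 2 `COc1ccc2nc(COc3ccc(CC(C(N)=O)[S+](C)[O-])cc3)n(C)c2c1`: 33.9 ng.h/mL

Within the data shown here, compound 2 holds the higher of these two numbers, and the one measured step between them is large: a 13-fold higher number from compound 1 to compound 2 (1.10 log units; beyond the scatter). Compound 3 `COc1ccc2nc(COc3ccc(CC(SC)C(=O)O)cc3)n(C)c2c1` has not been measured yet. The change from compound 2 is this: a group of 6 heavy atoms (3 carbon, 2 oxygen, 1 sulfur; no ring) in place of a group of 7 heavy atoms (3 carbon, 1 nitrogen, 2 oxygen, 1 sulfur; no ring), on a saturated chain carbon bound to an aromatic carbon. In effect, two things happen at once. The sulfur returns to the form seen in compound 1, and the amide of both measured compounds gives way to a carboxy group.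

Only the sulfur part has a measured step to go on. Undoing a 13-fold higher number from compound 1 to compound 2 (1.10 log units; beyond the scatter) on its own would pull the number down by that same large size. Among the measured compounds shown here, no measured step covers the carboxy group, so its effect could run in either direction and might offset the sulfur part. The expected change is a 1.3-fold higher number from compound 2 to compound 3 (0.12 log units; within the scatter), so no clear step beyond the scatter is expected, though with wide uncertainty. For compound 3 the estimate is 45 ng.h/mL, with an expected range from 6 ng.h/mL to 300 ng.h/mL.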

Compound 3, area under the concentration-time curve: 3.29 ng.h/mL
Estimate against measurement, compound 3: 14-fold (1.14 log units) above; the measured number lies below the stated range.
By their numbers in this assay, from the lowest: compounds 1 and 3 (each within the scatter of the next); then compound 2.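

In this assay, with the methylsulfanyl group kept on the chain, hydroxy in place of amino on the carbonyl carbon gives a change that stays within the scatter (a 1.2-fold higher number from compound 1 to compound 3 (0.08 log units; within the scatter)), so amide and carboxy cannot be told apart in this sulfur form. The step that changes the sulfur and the amide together is large (a 10-fold lower number from compound 2 to compound 3 (1.01 log units; beyond the scatter)), and it leaves compound 2 alone at the high end, with compounds 1 and 3 together at the low end. Among these three compounds, then, only the compound with oxygen on the sulfur stands apart, and none goes against that pattern, though three compounds are a very small base for it. Nothing given here explains these numbers.

As far as these compounds go, what remains open is whether amino and hydroxy would also read alike with oxygen on the sulfur, as the carboxy group appears here only with the methylsulfanyl form. From the compounds shown here alone, it is also open how a sulfone, with two oxygens on the sulfur, or a methyl ester in place of the carboxy group would stand on this read-out.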